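Chloro and carbamoyl on the pyridine ether of the quinolone amides

A few compounds are considered here, and "the series" means these few. Any claim that something is new, unique, unknown or untested is made for them only; others in the source may bear on it.

Measured compounds in an assay on isolated protein for inhibition of tyrosine-protein kinase receptor UFO (Homo sapiens), read by FRET and Z'-LYTE, with a stated time of 1.5 h; on this read-out lower numbers stand for stronger inhibition and higher numbers for weaker inhibition:
compound 1, `CCc1ccc2c(c1)c(=O)c(C(=O)Nc1ccc(Oc3ccnc(N)c3)c(F)c1)c(C)n2C`: 888 nM
compound 2, `CCc1ccc2c(c1)c(=O)c(C(=O)Nc1ccc(Oc3ccnc(C(N)=O)c3)c(F)c1)c(C)n2C`: 4380 nM
compound 3, `CCc1ccc2c(c1)c(=O)c(C(=O)Nc1ccc(Oc3ccnc(N)c3Cl)c(F)c1)c(C)n2C`: 72 nM

Compound 3 stands lowest of the three, and both of its steps to the others lie beyond the scatter. From compound 1 it differs by chloro in place of hydrogen on an aromatic carbon, and that change gave a 12-fold lower number from compound 1 to compound 3 (1.09 log units; beyond the scatter). From compound 2 the gap is wider still, a 61-fold lower number from compound 2 to compound 3 (1.78 log units; beyond the scatter).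

The step from compound 1 to compound 2 is carbamoyl in place of amino on an aromatic carbon, and it cost a 4.9-fold higher number from compound 1 to compound 2 (0.69 log units; beyond the scatter).

Compound 4, `CCc1ccc2c(c1)c(=O)c(C(=O)Nc1ccc(Oc3ccnc(C(N)=O)c3Cl)c(F)c1)c(C)n2C`, is not yet measured. It differs from compound 3 by carbamoyl in place of amino on an aromatic carbon. This is the same kind of change as that from compound 1 to compound 2, made on the core of compound 3 rather than on the core of compound 1; the two cores differ by the chloro in place of hydrogen described above. Around the place the two surroundings are not identical: in compound 3 the amino that leaves sits ortho to a chloro group (1 heavy atom), which was not there in compound 1. From the compounds shown here alone, the change is seen only once in measured form, so the size of its step with the chloro present is unknown.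

Within the data shown here, the expectation for compound 4 in this assay is a step of about the same size as the earlier one, a 4.6-fold higher number from compound 3 to compound 4 (0.66 log units; beyond the scatter), because the only measured instance is a 4.9-fold higher number from compound 1 to compound 2 (0.69 log units; beyond the scatter). With that, compound 4 is estimated at 330 nM, with a range from 110 nM to 1100 nM, the width reflecting that the chloro neighbour may alter the size of the step in either direction.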

Compound 4, half-maximal inhibitory concentration: > 10000 nM
Compound 4: no number, only a limit; the forecaster's own chance of this, stated with the estimate: 2%; at least 30-fold (1.48 log units) between middle value and limit.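

In this assay compound 4 gives > 10000 nM, which is a limit of the assay and not a number, so every step to compound 4 fixes only a minimum size and its full size remains unread. With the chloro present, carbamoyl in place of amino gives an at least 130-fold higher number from compound 3 to compound 4 (2.14 log units; beyond the scatter), so in this series the step does not carry over at the same size from one core to the other: the same change on two cores in this assay, a 4.9-fold higher number (0.69 log units; beyond the scatter) from compound 1 to compound 2 and an at least 130-fold higher number (2.14 log units; beyond the scatter) from compound 3 to compound 4, at least 28-fold (1.44 log units) apart, beyond the scatter of two such steps. Read the other way, chloro in place of hydrogen gives a 12-fold lower number from compound 1 to compound 3 (1.09 log units; beyond the scatter) with amino in the place but an at least 2.2-fold higher number from compound 2 to compound 4 (0.35 log units; beyond the scatter) with carbamoyl, and the two changes together give an at least 11-fold higher number from compound 1 to compound 4 (1.05 log units; beyond the scatter), so the two changes do not add up independently on these four compounds, although one such set shows nothing about other cores: the same change on two cores in this assay, a 12-fold lower number (1.09 log units; beyond the scatter) from compound 1 to compound 3 and an at least 2.2-fold higher number (0.35 log units; beyond the scatter) from compound 2 to compound 4, at least 28-fold (1.44 log units) apart, beyond the scatter of two such steps.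

The compounds shown leave open whether the large rise needs the chloro itself or would also appear with a fluoro or a methyl in its place. Also open, from the compounds shown here alone, is how a methylamino or a nitrile in place of the amino would behave with the chloro present, and how far the number for compound 4 lies beyond its limit.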